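The source may hold more compounds than are shown below. What is called first, only, known or untested is meant among the compounds shown, and "the series" means these compounds.

In a physicochemical assay for solubility, in simulated intestinal fluid, with a stated time of 4 h (a lower number here means a less soluble compound, a higher number a more soluble compound), compound 1 `N#Cc1ccc(O[C@H]2CN(S(=O)(=O)c3ccc(Cl)cc3Cl)C[C@@]2(O)CO)cc1F` gives 19 ug/mL. Compound 3 `N#Cc1ccc(O[C@H]2CN(S(=O)(=O)c3ccc(C(F)(F)F)cc3C#N)C[C@@]2(O)CO)cc1F` gives 25 ug/mL, within the scatter of compound 1, while compound 2 `N#Cc1ccc(O[C@H]2CN(S(=O)(=O)c3ccc(Cl)cc3Cl)C[C@]2(O)CO)cc1F` gives 88 ug/mL, beyond the scatter of compound 1. Compound 4 `N#Cc1ccc(O[C@H]2CN(S(=O)(=O)c3ccccc3C#N)C[C@@]2(O)CO)cc1F` carries 2-cyanophenyl in place of 2,4-dichlorophenyl on a sulfonyl sulfur. Among the measured compounds shown here, the one measured step, a 4.6-fold higher number from compound 1 to compound 2 (0.67 log units; beyond the scatter), is modest and goes with the fact that compounds 1 and 2 differ only in the configuration as drawn, so it leaves that group untouched and offers only a sense of scale. Compound 3 shares the configuration of compound 1 and also carries a nitrile, yet the two values stay within the scatter. No step beyond the scatter is therefore expected in this assay. The expected step is a 1.5-fold higher number from compound 1 to compound 4 (0.17 log units; within the scatter). For compound 4 the estimate is 28 ug/mL, with an expected range of 11 ug/mL to 70 ug/mL.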

Compound 4, solubility: 20 ug/mL
Compound 4: the middle estimate sits 1.4-fold (0.15 log units) above what was measured; the range from low to high includes it.
By their numbers in this assay, from the lowest: compounds 1, 4 and 3 (each within the scatter of the next); then compound 2.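

Setting 2-cyanophenyl in place of 2,4-dichlorophenyl on a sulfonyl sulfur gives a 1.1-fold higher number from compound 1 to compound 4 (0.02 log units; within the scatter) in this assay and so shows that this position takes the exchange without a step beyond the scatter. Hydrogen in place of trifluoromethyl on an aromatic carbon gives a 1.3-fold lower number from compound 3 to compound 4 (0.10 log units; within the scatter) and likewise stays within the scatter. Nothing in the evidence at hand bears on these two steps.

Open, from the compounds shown here alone, is whether an aryl group carrying an amine or a carboxylic acid at this sulfonyl sulfur would stay within the scatter. Also open, going by these compounds, is whether 2-cyanophenyl would show a step like a 4.6-fold higher number from compound 1 to compound 2 (0.67 log units; beyond the scatter) in the configuration of compound 2.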